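Solubility notes: aryl ether to directly bound aryl

The source may report more compounds than this note shows. Statements on the series, on what has been measured and on what is new or still open speak of the compounds shown alone.

In a physicochemical assay for solubility, with a stated time of 18 h, at pH 7.4 (on this read-out lower numbers stand for lower solubility and higher numbers for higher solubility), compound 1 `COc1ccc(Oc2ccc3c(NCCCNCc4cccc(OC)c4O)ccnc3c2)cc1` gives 14500 nM, level with compound 3 `COc1ccc(Oc2ccc3c(NCCCNCc4ccco4)ccnc3c2)cc1` at 14500 nM, the two together the lowest of the three numbers. Compound 2 `COc1cccc(CNCCCNc2ccnc3cc(-c4cc(C(F)(F)F)cc(C(F)(F)F)c4)ccc23)c1O` gives 32000 nM, a number beyond the scatter above compound 1. The step of no change at the digits printed from compound 1 to compound 3 (within the scatter) concerns the amine end of the chain, not the aromatic carbon altered here. Compound 4 `COc1ccc(-c2ccc3c(NCCCNCc4cccc(OC)c4O)ccnc3c2)cc1` differs from compound 1 by 4-methoxyphenyl in place of 4-methoxyphenoxy on an aromatic carbon. Within the data shown here, no measured step covers this change alone; compound 2 also carries a directly bound aryl ring, yet it differs from compound 1 in a second place as well, and its higher number is at most a weak pointer. The step from compound 1 to compound 4 is therefore expected as a 1.0-fold higher number from compound 1 to compound 4 (0.01 log units; within the scatter), within the scatter. Compound 4 is estimated at 15000 nM, between 6000 nM and 36000 nM.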

Compound 4, solubility: 32000 nM
Estimate against measurement, compound 4: 2.1-fold (0.33 log units) below, within the range that was stated.
By their numbers in this assay, from the lowest: compounds 1 and 3 (each within the scatter of the next); then compounds 2 and 4 (each within the scatter of the next).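

In this assay the change at this aromatic carbon now has its own reading, with 4-methoxyphenyl in place of 4-methoxyphenoxy: a 2.2-fold higher number from compound 1 to compound 4 (0.34 log units; beyond the scatter), a modest step beyond the scatter. Compound 4 gives 32000 nM and compound 2, which also carries a directly attached aryl ring, gives 32000 nM, the same printed number. No measurement here accounts for the step. Still open, going by these compounds, is how a morpholine on this aromatic carbon would read, and whether the step holds with furan-2-yl on the chain, as in compound 3.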